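This account rests on a few compounds, and the source may have more. Where it says the series, first, only, none or still open, it means among the compounds named here.

Measured compounds:
Compound 1 `COc1ccccc1-n1nncc1CN1C(=O)C2(C(C#N)=C(N)Oc3c2c2nc4ccccc4nc2c2ccccc32)c2ccccc21` gives in a functional assay on MCF7 cells (Homo sapiens) for antiproliferative activity, read by MTT assay, with a stated time of 48 h (on this read-out higher numbers stand for weaker inhibition and lower numbers for stronger inhibition), only a limit, > 50000 nM.
Compound 2 `N#CC1=C(N)Oc2c(c3nc4ccccc4nc3c3ccccc23)C12C(=O)N(Cc1cnnn1-c1ccc(F)c(Cl)c1)c1ccccc12` likewise gives only a limit, > 50000 nM.
Compound 3 `N#CC1=C(N)Oc2c(N)cc3nc4ccccc4nc3c2C12C(=O)N(Cc1cnnn1-c1cccc(C(F)(F)F)c1)c1ccccc12` gives 31600 nM.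

Compound 3 is thus the only one of the three with a number in this assay; the other two values are limits (the limit of > 50000 nM in this assay, at which 2 of the 3 values shown sit). Compound 4 `N#CC1=C(N)Oc2c(N)cc3nc4ccccc4nc3c2C12C(=O)N(Cc1cnnn1-c1ccc(F)c(Cl)c1)c1ccccc12` is the next compound of the series. It differs from compound 3 in one place: 3-chloro-4-fluorophenyl in place of 3-(trifluoromethyl)phenyl on an aromatic nitrogen. One measured step shares the entering group, a step that the two limits leave unreadable from compound 1 to compound 2; both of its ends are limits, so it yields no size. Within the data shown here, no measured step thus tells how far the change from compound 3 to compound 4 moves the value, and with no readable precedent no shift beyond the scatter is assumed. Compound 4 is expected to sit near compound 3, at 35000 nM (range 12000 nM to 100000 nM). The expected step, a 1.1-fold higher number from compound 3 to compound 4 (0.04 log units; within the scatter), is estimated to lie within the scatter. Since compound 3 already sits close to the limit of this assay, the result for compound 4 may well come back as a limit rather than a number.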

Compound 4, half-maximal inhibitory concentration: 17800 nM
Compound 4: middle estimate off by 2.0-fold (0.29 log units), on the high side; measured number inside the range.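

The exchange on the aromatic nitrogen has its first readable size in this assay as a 1.8-fold lower number from compound 3 to compound 4 (0.25 log units; within the scatter) on the core shared by compound 3 and compound 4. The 3-(trifluoromethyl)phenyl and 3-chloro-4-fluorophenyl groups are therefore not told apart on this core, and both compounds give numbers rather than limits. The step from compound 1 to compound 2 cannot be read, so this one pair is all that speaks for the position, while compound 1 and compound 2 remain limits: the limit of > 50000 nM in this assay, at which 2 of the 4 values shown sit.

Still open, as far as these compounds go, is whether any substituent on this phenyl ring moves the value beyond the scatter, for example an amine or a carboxylic acid in place of the halogens. Also open, from the compounds shown here alone, is whether the 2-methoxyphenyl group gives a number on the core of compound 3.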